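The source may hold more compounds than are shown below. What is called first, only, known or untested is meant among the compounds shown, and "the series" means these compounds.

Within the data shown here, in a functional assay on DU-145 cells (Homo sapiens) for cytotoxicity, read by MTT assay, with a stated time of 48 h (on this read-out higher numbers stand for weaker inhibition and lower numbers for stronger inhibition), compound 1 `O=C(Nc1nc2ccc(F)cc2s1)c1cc(-c2ccc(F)cc2)n2nc(-c3ccccc3)cc2n1` gives 22900 nM and compound 2 `COc1ccc(-c2cc(C(=O)Nc3nc4ccc(F)cc4s3)nc3cc(-c4ccccc4)nn23)cc1OC` gives 18600 nM; the two lie within the scatter of each other, the only measured step being a 1.2-fold lower number from compound 1 to compound 2 (0.09 log units; within the scatter), 3,4-dimethoxyphenyl in place of 4-fluorophenyl. Compound 3 `COc1cc(-c2cc(C(=O)Nc3nc4ccc(F)cc4s3)nc3cc(-c4ccccc4)nn23)cc(OC)c1OC` carries methoxy in place of hydrogen on an aromatic carbon, on an aromatic carbon ortho to a methoxy group and meta to a large group, so that 3,4-dimethoxyphenyl becomes 3,4,5-trimethoxyphenyl. The step from compound 1 to compound 2 is the only one that bears on this change, and it stayed within the scatter, so no shift beyond the scatter is expected in this assay. Compound 3 is therefore estimated at 17000 nM, with a range of 8000 nM to 40000 nM. The expected step is a 1.1-fold lower number from compound 2 to compound 3 (0.04 log units; within the scatter).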

Compound 3, half-maximal inhibitory concentration: 25700 nM
Beside the measured number, compound 3's estimate is 1.5-fold (0.18 log units) below it; the measured number falls inside the stated range.
By their numbers in this assay, from the lowest: compounds 2, 1 and 3 (each within the scatter of the next).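

In this assay, methoxy in place of hydrogen on the aromatic carbon ortho to a methoxy group gives a 1.4-fold higher number from compound 2 to compound 3 (0.14 log units; within the scatter) and 3,4,5-trimethoxyphenyl in place of 4-fluorophenyl gives a 1.1-fold higher number from compound 1 to compound 3 (0.05 log units; within the scatter). This position therefore takes a third methoxy with no shift beyond the scatter, and the three aryl groups shown do not separate from one another. Nothing available explains this result.

From the compounds shown here alone, whether an amine or a carboxylic acid on this aryl ring would move the number beyond the scatter stays open. So does whether any change to the shared core would do so.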